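Replacing 3-bromophenyl with 4-methoxyphenyl: an expected step

The source may hold more compounds than are shown below. What is called first, only, known or untested is meant among the compounds shown, and "the series" means these compounds.

Compound 1 `CCN1CCN(c2ccc(S(=O)(=O)Oc3cccc(F)c3)cc2)C1=O` (value 11000 nM)
Compound 2 `CCN1CCN(c2ccc(S(=O)(=O)Oc3cccc(Cl)c3)cc2)C1=O` (value 3900 nM)
Compound 3 `CCN1CCN(c2ccc(S(=O)(=O)Oc3cccc(Br)c3)cc2)C1=O` (value 3400 nM)

In a functional assay on M21 cells (Homo sapiens) for antiproliferative activity, read by sulforhodamine B assay, with a stated time of 48 h (on this read-out higher numbers stand for weaker inhibition and lower numbers for stronger inhibition), compound 2 and compound 3 stand together at the low end of the three numbers, with a 1.1-fold lower number from compound 2 to compound 3 (0.06 log units; within the scatter) separating them. Compound 1 stands apart from both, as shown by a 2.8-fold lower number from compound 1 to compound 2 (0.45 log units; beyond the scatter) and by a 3.2-fold lower number from compound 1 to compound 3 (0.51 log units; beyond the scatter) on the same read-out.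

Compound 4 `CCN1CCN(c2ccc(S(=O)(=O)Oc3ccc(OC)cc3)cc2)C1=O` brings one change, 4-methoxyphenyl in place of 3-bromophenyl on an oxygen in the form of 4-methoxyphenyl in place of 3-bromophenyl on an oxygen. Among the compounds with values here, no measured compound carries a methoxy group, so the three halogen steps bear on this change only indirectly. They do show that exchanging a single substituent on this aryl group moved the number modestly at most, and compound 1 at 11000 nM shows that such a move can go upward. A modest rise is therefore expected, namely a 1.8-fold higher number from compound 3 to compound 4 (0.25 log units; within the scatter) as estimated here, with wide uncertainty. For compound 4 the expected value is 6000 nM (estimated range 1800 nM to 18000 nM).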

Compound 4, half-maximal inhibitory concentration: 26000 nM
The estimate for compound 4 lay 4.3-fold (0.64 log units) below the measured number, and the stated range ends below it.
By their numbers in this assay, from the lowest: compounds 3 and 2 (each within the scatter of the next); then compound 1; then compound 4.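

In this assay, 4-methoxyphenyl on the oxygen bound to the sulfonyl sulfur gives a higher number than any of the three halogen-bearing aryl groups, with a 7.6-fold higher number from compound 3 to compound 4 (0.88 log units; beyond the scatter) and a 6.7-fold higher number from compound 2 to compound 4 (0.82 log units; beyond the scatter), and also a 2.4-fold higher number from compound 1 to compound 4 (0.37 log units; beyond the scatter). The halogen exchanges had therefore shown only part of the range at this position, and compound 4 is the weakest of the four on this read-out. Nothing available accounts for this rise.

As far as these compounds go, whether the rise belongs to the methoxy group itself or to its place on the aryl ring stays open, and a 3-methoxyphenyl or a 4-bromophenyl group would help separate the two. From the compounds shown here alone, how an unsubstituted phenyl group or a 3-aminophenyl group would compare also remains unknown.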